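Working notes on the step from compound 3 to compound 4

This account rests on a few compounds, and the source may have more. Where it says the series, first, only, none or still open, it means among the compounds named here.

Compound 1 `Nc1cc(N)c2nc(-c3ccccc3)c(Oc3ccc(Cl)c(Cl)c3)nc2c1` carries a 3,4-dichlorophenoxy group; in a functional assay on OVCAR-3 cells (Homo sapiens) for inhibition, read by sulforhodamine B assay, with a stated time of 48 h (a higher number here means a weaker inhibitor of growth, a lower number a stronger inhibitor of growth), compound 1 gives 26900 nM. Compound 2 `CCOC(=O)[C@H](CCC(=O)O)NC(=O)c1ccc(CNc2nc3cc(N)cc(N)c3nc2-c2ccccc2)cc1` is read only as a limit of the assay, and in this assay compound 2 gives < 100000 nM. Compound 3 `COc1ccc(Sc2nc3cc(N)cc(N)c3nc2-c2ccccc2)cc1` likewise stands at a limit in this assay, where compound 3 gives < 100000 nM. The change between them, a step that the limit leaves unreadable from compound 1 to compound 3, cannot be sized, since two of the three values sit at the limit of < 100000 nM in this assay, at which 2 of the 3 values shown sit. Compound 4 `Nc1cc(N)c2nc(-c3ccccc3)c(Oc3ccc(F)cc3)nc2c1` differs from compound 3 by 4-fluorophenoxy in place of (4-methoxyphenyl)sulfanyl on an aromatic carbon. Going by the values given here, the only measured step bearing on this move is the unreadable one from compound 1 to compound 3, so no measured step sizes it. Compound 4 carries a 4-fluorophenoxy group, structurally nearer to compound 1, which gives 26900 nM, than to compound 3. In this assay compound 4 is therefore expected near 40000 nM, within 15000 nM to 100000 nM. The expected step is a step that the limit leaves unreadable from compound 3 to compound 4, and whether it reaches beyond the scatter cannot be told while compound 3 is known only as a limit.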

Compound 4, concentration for total growth inhibition: 41700 nM
Estimate against measurement, compound 4: 1.0-fold (0.02 log units) below; measured number inside the range.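

In this assay, this position, on an aromatic carbon next to the ring nitrogen, now has a second aryl ether with a readable value, and the comparison gives a 1.6-fold higher number from compound 1 to compound 4 (0.19 log units; within the scatter). Between compound 1 and compound 4, 4-fluorophenyl and 3,4-dichlorophenyl on the oxygen are therefore not told apart by this read-out. The steps to and from compound 3 cannot be read, because compound 3 stands at a limit of the assay: the limit of < 100000 nM in this assay, at which 2 of the 4 values shown sit.

The compounds shown leave open how a sulfur link compares with an oxygen link when the aryl group stays the same. They also leave open how this assay would read with a morpholine or a nitrile at this position in place of the aryl ether.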